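Stretching the Amide Cap Toward a Longer Aryl Chain

This account rests on a few compounds, and the source may have more. Where it says the series, first, only, none or still open, it means among the compounds named here.

Three measured compounds share a common core and differ only in the groups attached around it. In an assay on THP-1 cells for displacement of a labelled ligand from C-C chemokine receptor type 1 (Homo sapiens) (a higher number here means a weaker inhibitor, a lower number a stronger inhibitor), compound 1 `CC[C@@H](NC(=O)c1ccccc1)C(=O)N1CCC(c2ccc(Cl)cc2)CC1` gives 121 nM, compound 2 `CC(C)C(NC(=O)c1ccccc1)C(=O)N1CCN(c2ccc(Cl)cc2)CC1` gives 525 nM, and compound 3 `CC(C)[C@@H](NC(=O)c1cccc(F)c1)C(=O)N1CCC(c2ccc(Cl)cc2)CC1` gives 24 nM. Compound 3 therefore stands with the lowest number of the three: compound 1 is its nearest neighbour, yet separated from it by more than the usual scatter, and compound 2 lies furthest away, also well beyond the scatter.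

Compound 4 `Cc1cccc(CCC(=O)N[C@@H](C(=O)N2CCC(c3ccc(Cl)cc3)CC2)C(C)C)c1` has not yet been measured. It differs from compound 3 in a single place: 2-(3-methylphenyl)ethyl in place of 3-fluorophenyl on a carbonyl carbon. Within the data shown here, no pair among the measured compounds shows an exchange of this kind, so there is no measured step to lean on; the only guidance is that compound 3 gives 24 nM and the new group is larger and no longer carries a fluorine. The change is expected to move the number somewhat toward weaker binding, with a step of a 2.5-fold higher number from compound 3 to compound 4 (0.40 log units; beyond the scatter) that could still fall within the scatter. For compound 4 in this assay the estimate is 60 nM, within a range from 15 nM to 250 nM.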

Compound 4, half-maximal inhibitory concentration: 22 nM
Beside the measured number, compound 4's estimate is 2.7-fold (0.44 log units) above it, and the stated range covers the measured number.
By their numbers in this assay, from the lowest: compounds 4 and 3 (each within the scatter of the next); then compound 1; then compound 2.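

In this assay, putting 2-(3-methylphenyl)ethyl in place of 3-fluorophenyl on a carbonyl carbon gives a step too small to separate the two compounds (a 1.1-fold lower number from compound 3 to compound 4 (0.04 log units; within the scatter)). Among these compounds, this is the first measured exchange at this position, and it shows that the position accepts a larger group made only of carbon, with the aromatic ring now carried on an ethyl chain, and with no measurable loss. For this pair, then, neither the fluorine nor the ring's attachment straight to the carbonyl carbon is needed for a value at this level, and no measurement shown here accounts for the match.

The compounds shown leave open which part of the new group matters, the ethyl chain or the methyl, as both arrive together with the loss of the fluorine. A plain 2-phenylethyl group would pull those parts apart, while a longer chain such as 3-phenylpropyl, or a carboxylic acid on the ring, would test how much more this position tolerates.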